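Amide-linked basic amines on the shared core

The source may report more compounds than this note shows. Statements on the series, on what has been measured and on what is new or still open speak of the compounds shown alone.

Measured so far in an assay on CHO cells for inhibition of Vasopressin V2 receptor (Homo sapiens), read by radioligand binding; a higher number here means a weaker inhibitor, a lower number a stronger inhibitor:
compound 1 `CN1CCN(C(=O)CCCOc2cc(C(=O)N3CCCCc4sccc43)ccc2NC(=O)c2ccccc2-c2ccccc2)CC1`, 6 nM
compound 2 `CN1CCN(CCCCOc2cc(C(=O)N3CCCCc4sccc43)ccc2NC(=O)c2ccccc2-c2ccccc2)CC1`, 1 nM

Going by the values given here, compound 1 gives the higher of the two numbers; the only step available runs a 6.0-fold lower number from compound 1 to compound 2 (0.78 log units; beyond the scatter), and that step changes the linkage of the basic amine to the chain, not the amine itself.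

Compound 3 `CCN(CC)C1CCN(C(=O)CCCOc2cc(C(=O)N3CCCCc4sccc43)ccc2NC(=O)c2ccccc2-c2ccccc2)CC1` keeps the carbonyl linkage of compound 1 and alters the amine: 4-(diethylamino)piperidin-1-yl in place of 4-methylpiperazin-1-yl on a carbonyl carbon. Among the compounds with values here, no measured pair covers a swap of one basic ring amine for another under a retained carbonyl, so the step from compound 1 to compound 2 does not bear on it directly; it only shows that this region tolerates change without loss. With the linkage held and only the ring amine exchanged, no shift beyond the scatter is expected, and compound 3 is estimated at 5 nM, range 2 nM to 15 nM, a step of a 1.2-fold lower number from compound 1 to compound 3 (0.08 log units; within the scatter).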

Compound 3, half-maximal inhibitory concentration: 9 nM
Compound 3: middle estimate off by 1.8-fold (0.26 log units), on the low side, and the stated range covers the measured number.
By their numbers in this assay, from the lowest: compound 2; then compounds 1 and 3 (each within the scatter of the next).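

In this assay, with the carbonyl linkage held, the exchange of 4-methylpiperazin-1-yl for 4-(diethylamino)piperidin-1-yl gives a 1.5-fold higher number from compound 1 to compound 3 (0.18 log units; within the scatter). The earlier pair changed only the linkage, whereas this pair changes the ring amine itself, and the entering group, at 11 heavy atoms against 7 and with one ring hetero atom against 2, brings no shift beyond the scatter. Nothing available accounts for this outcome.

Still open, as far as these compounds go, is whether 4-(diethylamino)piperidin-1-yl on the carbonyl-free chain of compound 2 would follow the same course as 4-methylpiperazin-1-yl. Also open, from the compounds shown here alone, is how a morpholin-4-yl ring or an open-chain dimethylamino group on the same carbonyl carbon would read, and whether a longer chain to the aromatic oxygen changes the picture.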